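This account rests on a few compounds, and the source may have more. Where it says the series, first, only, none or still open, it means among the compounds named here.

Compound 1 `COc1cc2c(Nc3nc4ccc(C(=O)Nc5c(C)cccc5C)cc4s3)ncnc2cc1OCCCN1CCCC1` is inactive as far as the numbers go. In a functional assay on HCT-116 cells (Homo sapiens) for cytotoxicity, read by WST assay, with a stated time of 72 h (a higher number here means a weaker inhibitor, a lower number a stronger inhibitor), compound 1 reaches only the limit of the assay, > 100000 nM, which is not a number. Its companion compound 2 `COc1cc2c(Nc3nc4ccc(C(=O)Nc5c(C)cccc5C)cc4s3)ncnc2cc1OCCCN1CCC(C)CC1` shares the whole core and differs only in the ring at the end of the chain. In this assay compound 2 likewise stops at the limit, > 100000 nM. The step that the two limits leave unreadable from compound 1 to compound 2 therefore cannot be sized. Going by the values given here, what the two values together show is the limit of > 100000 nM in this assay, at which 2 of the 2 values shown sit: no measured step in this set has a readable size.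

Compound 3 `COc1cc2c(Nc3nc4ccc(C(=O)Nc5c(C)cccc5Cl)cc4s3)ncnc2cc1OCCCN1CCCC1` changes the amide end of compound 1: chloro in place of methyl on an aromatic carbon. Among the compounds with values here, no measured step touches this part of the molecule, so nothing indicates how large a step to expect in this assay, in either direction; the one comparison available sits entirely at the limit. The estimate for the step from compound 1 to compound 3 is accordingly a number no higher from compound 1 to compound 3 (the limit leaves the size open), meaning no change beyond the scatter is expected. Compound 3 is expected to give about 100000 nM in this assay, between 30000 nM and 300000 nM, most likely again reported only as a limit.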

Compound 3, half-maximal inhibitory concentration: 63800 nM
Compound 3: the middle estimate sits 1.6-fold (0.20 log units) above what was measured, and the stated range covers the measured number.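

In this assay, going by these compounds alone, chloro in place of methyl on an aromatic carbon, ortho to a large group, gives the first step in this set that has a readable size, an at least 1.5-fold lower number from compound 1 to compound 3 (0.19 log units; that floor lies within the scatter). That size is only a floor, since compound 1 stands at a limit of the assay: the true gap may be larger, but what is printed does not place it beyond the scatter, so the change at this position cannot yet be called a real gain. Even so, compound 3 is the one compound shown that returns a number rather than a limit, and the change that brings this about lies at the amide end, not at the ring at the end of the chain: the limit of > 100000 nM in this assay, at which 2 of the 3 values shown sit.

The compounds shown leave open whether a fluoro, a bromo or a methoxy at this position, or a second chloro in place of the remaining methyl, would move the number further. They also leave open whether the same chloro for methyl change would give a readable number when paired with the 4-methylpiperidin-1-yl end of compound 2.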